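Methoxy in Place of Hydrogen at a Second Aromatic Carbon

A few compounds are considered here, and "the series" means these few. Any claim that something is new, unique, unknown or untested is made for them only; others in the source may bear on it.

Compound 1, `Nc1nc(NCc2ccccc2)nc(-c2ccccc2CO)n1`, in a functional assay on cells for positive allosteric modulation of G-protein coupled receptor 68 (Homo sapiens), read by a luciferase reporter and cAMP accumulation, with a stated time of 30 min, at pH 6.8 and pH 8.3, in the presence of a further agent that is not named here (a lower number here means a less potent compound, a higher number a more potent compound, by a factor of ten per unit of this negative logarithm), gives 4.35.
Compound 2, `Nc1nc(NCc2ccccc2)nc(-c2cc(Cl)ccc2CO)n1`, in this assay gives 4.49.
Compound 3, `COc1cccc(-c2nc(N)nc(NCc3ccccc3)n2)c1CO`, in this assay gives 4.16.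

Compound 1 stands second highest of the three: the step of a number 0.14 log units higher from compound 1 to compound 2 (within the scatter) and the step of a number 0.19 log units lower from compound 1 to compound 3 (within the scatter) are both within the scatter, so the three compounds are indistinguishable here. Compound 4, `COc1ccc(-c2nc(N)nc(NCc3ccccc3)n2)c(CO)c1`, differs from compound 1 by methoxy in place of hydrogen on an aromatic carbon. Going by the values given here, the step from compound 1 to compound 3 is the closest precedent, a methoxy entering at another aromatic carbon of the same ring, and it stayed within the scatter, as did the chloro step to compound 2. No step beyond the scatter is therefore expected in this assay. Compound 4 is estimated at 4.3, between 3.9 and 4.7, an expected step of a number 0.05 log units lower from compound 1 to compound 4 (within the scatter).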

Compound 4, negative logarithm of the antagonist equilibrium constant: 4.12
Compound 4: the middle estimate sits 0.18 log units above what was measured, and the stated range covers the measured number.
By their numbers in this assay, from the lowest: compounds 4, 3, 1 and 2 (each within the scatter of the next, the first and the last beyond it).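

Methoxy on this aromatic carbon, para to a large group and meta to a hydroxymethyl group, gives a number 0.23 log units lower from compound 1 to compound 4 (within the scatter) in this assay and so adds a second carbon of the ring where this change stays within the scatter, as it did in compound 3. The position therefore accepts methoxy without a measurable change in this read-out. Nothing shown bears on the reason for this.

As far as these compounds go, whether an amine or a carboxylic acid on this carbon would stay within the scatter remains open. So does the outcome for a longer chain such as ethoxy, or for chloro, which appears only at another carbon in compound 2.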